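Two nucleoside limits and a methylamino analogue

This account rests on a few compounds, and the source may have more. Where it says the series, first, only, none or still open, it means among the compounds named here.

Compound 1 `CN(C)c1nc(N)c2ncn([C@@H]3C[C@@H](O)[C@H](CO)O3)c2n1` — > 300 uM
Compound 2 `CSc1nc(SC)c2ncn([C@@H]3C[C@@H](O)[C@H](CO)O3)c2n1` — > 300 uM

Both measured compounds share the same sugar-bearing core. In a functional assay on K562 cells (Homo sapiens) (on this read-out lower numbers stand for stronger inhibition and higher numbers for weaker inhibition), compound 1 gives > 300 uM, which is a limit of the assay and not a number. In this assay compound 2 likewise gives > 300 uM, again a limit of the assay rather than a measured number. Among the compounds with values here, compound 2 therefore stands at the limit of > 300 uM in this assay, at which 2 of the 2 values shown sit, so the two values show nothing beyond that both sit at the same limit, and no step between them can be sized.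

Compound 3 `CNc1nc(SC)nc2c1ncn2[C@@H]1C[C@@H](O)[C@H](CO)O1` is to be measured in this assay. It differs from compound 2 by methylamino in place of methylsulfanyl on an aromatic carbon. Within the data shown here, since compound 2 sits at a limit, no step between measured compounds gives a scale for this change. The expectation for compound 3 is that the step that the limit leaves unreadable from compound 2 to compound 3 stays within the scatter, most likely with the assay again reporting a limit. Compound 3 is thus estimated at 400 uM, with a range from 100 uM to 1500 uM.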

Compound 3, concentration for 50% inhibition: > 300 uM
Compound 3: no number, only a limit; the forecaster's own chance of this, stated with the estimate: 85%; the middle value is on the limit's open side.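

In this assay compound 3 gives > 300 uM, again a limit of the assay and not a number. The step from compound 2 to compound 3 therefore cannot be read, since all the values sit at one limit: the limit of > 300 uM in this assay, at which 3 of the 3 values shown sit. The compounds shown leave open which change to the shared core, if any, would bring a measurable value in this assay.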